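The source may report more compounds than this note shows. Statements on the series, on what has been measured and on what is new or still open speak of the compounds shown alone.

Compound 1 `CCCOc1cc(C(=O)N(C)C)nn1-c1ccccc1` gives 26.2% in a functional assay on the whole organism (strain Wistar) for inhibition, with Rattus norvegicus as the target, read by paw edema, with stated times of 30 min and 3 h, at a dose of 100 mg/kg by the oral route; a higher number here means more inhibition at the dose given (going by the name of the read-out), a lower number less inhibition.
Compound 2 `CCCCOc1cc(C(=O)NC)nn1-c1ccccc1` gives 65% in this assay.
Compound 3 `CCCCOc1cc(C(=O)N(C)C)nn1-c1ccccc1` gives 18.7% in this assay.

Compound 3 has the lowest of the three numbers; compound 1 sits within the scatter of it, while compound 2 lies well above. The change to compound 4 `CCCCNC(=O)c1cc(OCCCC)n(-c2ccccc2)n1` is butylamino in place of dimethylamino on a carbonyl carbon. The step that bears on it is the one at the amide-type nitrogen, a number 46.3 percentage points lower from compound 2 to compound 3 (beyond the scatter), which points to a gain when that nitrogen carries a hydrogen again. The other step, a number 7.5 percentage points lower from compound 1 to compound 3 (within the scatter), concerns the ether chain and says little here. Going by the values given here, the swap of methyl for butyl on that nitrogen has no measured counterpart, which widens the uncertainty. A large rise in this assay is expected, a number 31.3 percentage points higher from compound 3 to compound 4 (beyond the scatter). Compound 4 is estimated at 50%, between 25% and 75%.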

Compound 4, a percentage reported as inhibition, in the whole organism at one dose (the size of the read-out at that dose, not a potency): 43.3%
Compound 4: middle estimate off by 6.7 percentage points, on the high side; measured number inside the range.
By their numbers in this assay, from the lowest: compounds 3 and 1 (each within the scatter of the next); then compound 4; then compound 2.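

With a hydrogen back on the nitrogen, a butyl group recovers much of the response lost by dimethylamino in this assay (a number 24.6 percentage points higher from compound 3 to compound 4 (beyond the scatter)). The hydrogen alone does not settle the outcome, however, since lengthening the methyl to butyl on a nitrogen that keeps its hydrogen still costs response (a number 21.7 percentage points lower from compound 2 to compound 4 (beyond the scatter)). No measured evidence explains either step.

Ethylamino and propylamino on the same carbonyl carbon remain open, so the shape of the trend with chain length is unknown. So does the plain amide, with two hydrogens on that nitrogen.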